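Cytotoxicity on fibroblast cells: swapping phenyl for dimethylcarbamoyl

A few compounds are considered here, and "the series" means these few. Any claim that something is new, unique, unknown or untested is made for them only; others in the source may bear on it.

Compound 1 `COC(=O)c1ccc(NCc2cncn2Cc2ccc(C#N)cc2)cc1-c1ccccc1`: in a toxicity assay on NIH3T3 cells (Mus musculus) for cytotoxicity, read by resazurin assay (on this read-out higher numbers stand for an effect only at larger amounts of compound and lower numbers for an effect already at smaller amounts), compound 1 gives > 10000 nM, a limit of the assay.
Compound 2 `c1ccc(-c2ccc(Cn3cncc3CNc3ccc(-c4ccccc4)c(-c4ccccc4)c3)cc2)cc1`: in this assay compound 2 gives > 10000 nM, again a limit.

Compound 2 therefore sits at the limit of > 10000 nM in this assay, at which 2 of the 2 values shown sit, so neither measured compound shows a toxic effect within the tested range. Compound 3 `CN(C)C(=O)c1ccc(NCc2cncn2Cc2ccc(-c3ccccc3)cc2)cc1-c1ccccc1` is not yet measured; it differs from compound 2 by dimethylcarbamoyl in place of phenyl on an aromatic carbon. With both measured values only limits, no step size can be drawn, and compound 3 is expected to move little beyond scatter, an expected step that the limit leaves unreadable from compound 2 to compound 3. Compound 3 is estimated at 15000 nM, ranging from 5000 nM to 50000 nM.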

Compound 3, half-maximal effective concentration: > 1000 nM
Compound 3: a limit, no number (the forecaster's own chance of this, stated with the estimate: 75%); the middle value does not contradict the limit.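

In this assay, among the compounds shown here, compound 3 gives > 1000 nM, a limit, so no step between compound 2 and compound 3 can be read. Whether dimethylcarbamoyl in place of phenyl changes cytotoxicity at all remains open, as does the concentration at which any of these compounds would show an effect.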